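Changing the Bicyclic Amide Group: Estimating Compound 4

This account rests on a few compounds, and the source may have more. Where it says the series, first, only, none or still open, it means among the compounds named here.

Compound 1, `O=C(NCc1ccc(S(=O)(=O)c2ccccc2)cc1)c1nc2cnccc2[nH]1`: in an assay for inhibition of Nicotinamide phosphoribosyltransferase (Homo sapiens), read by mass spectrometry, with stated times of 15 min and 30 min (a higher number here means a weaker inhibitor, a lower number a stronger inhibitor), compound 1 gives 7100 nM.
Compound 2, `O=C(NCc1ccc(S(=O)(=O)c2ccccc2)cc1)c1cn2ccnc2cn1`: in this assay compound 2 gives 150 nM.
Compound 3, `O=C(NCc1ccc(S(=O)(=O)c2ccccc2)cc1)c1c[nH]c2ccncc12`: in this assay compound 3 gives 1900 nM.

Compound 3 stands second highest of the three numbers, a weaker inhibitor than compound 2 and a stronger one than compound 1. Compound 4, `O=C(NCc1ccc(S(=O)(=O)c2ccccc2)cc1)c1cnc2nccn2c1`, differs from compound 3 only in the bicyclic group on the carbonyl carbon: a group of 9 heavy atoms (6 carbon, 3 nitrogen; one five-membered aromatic ring with 2 hetero atoms, one six-membered aromatic ring with 2 hetero atoms) in place of a group of 9 heavy atoms (7 carbon, 2 nitrogen; one five-membered aromatic ring with 1 hetero atom, one six-membered aromatic ring with 1 hetero atom), on a carbonyl carbon. In what is counted, the incoming group matches that of compound 2, with two hetero atoms in each ring and no hydrogen-bond donor, although the nitrogens sit differently. Among the measured compounds shown here, two measured steps bear on this. The related comparison between compound 2 and compound 3 was a 13-fold higher number from compound 2 to compound 3 (1.10 log units; beyond the scatter), and the change toward a group of this kind from compound 1 gave a 47-fold lower number from compound 1 to compound 2 (1.68 log units; beyond the scatter). A large decrease in the number is therefore expected, though the different nitrogen arrangement in compound 4 leaves room for a smaller gain. The estimated step is a 6.3-fold lower number from compound 3 to compound 4 (0.80 log units; beyond the scatter). Compound 4 is expected to give about 300 nM, within a range of 80 nM to 1500 nM.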

Compound 4, half-maximal inhibitory concentration: 2 nM
Estimate against measurement, compound 4: 150-fold (2.18 log units) above, outside the stated range (below it).
By their numbers in this assay, from the lowest: compound 4; then compound 2; then compound 3; then compound 1.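

In this assay, among the compounds shown here, changing only the bicyclic group on the carbonyl carbon gives a 950-fold lower number from compound 3 to compound 4 (2.98 log units; beyond the scatter) and a 3600-fold lower number from compound 1 to compound 4 (3.55 log units; beyond the scatter), a reach well beyond the steps among the earlier compounds. The most telling comparison is a 75-fold lower number from compound 2 to compound 4 (1.88 log units; beyond the scatter), as these two groups match in every count of atoms and rings and differ only in where their nitrogens sit, so at this position the arrangement of the nitrogens matters and not just their number. Nothing in the data given explains why this arrangement gives so much lower a number.

The compounds shown leave open which of the nitrogens in the group of compound 4 matters most. They also leave open whether the number stays this low with a methyl group or an amine added to that group.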